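Ethoxy in Place of Methyl: What to Expect

The compounds below may be only part of what the source reports. "The series", "measured", "known", "first", "only" and "open" are said of these compounds alone.

Measured so far in a functional assay on the whole organism (integument) for inhibition, with Chilo suppressalis as the target, read by scintillation counting, with a stated time of 72 h; a lower number here means a stronger inhibitor, a higher number a weaker inhibitor:
Compound 1, `O=C(Nc1nnc(-c2ccc(Cl)cc2)s1)c1ccccc1`, gives > 5010 nM, which is a limit of the assay and not a number.
Compound 2, `O=C(Nc1nnc(-c2ccc(Cl)cc2)s1)c1ccccc1Cl`, gives > 5010 nM, again a limit rather than a number.
Compound 3, `COc1cccc(OC)c1C(=O)Nc1nnc(-c2ccc(C)cc2)s1`, gives 1230 nM.

Among the measured compounds shown here, compound 3 therefore stands as the only compound of the three with an actual number in this assay; the other two values sit at the limit of > 5010 nM in this assay, at which 2 of the 3 values shown sit. For the measured compounds named here, the single measured step, a step that the two limits leave unreadable from compound 1 to compound 2, puts chloro in place of hydrogen on an aromatic carbon, but both of its ends are limits, so its size cannot be read.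

Compound 4, `CCOc1ccc(-c2nnc(NC(=O)c3c(OC)cccc3OC)s2)cc1`, has not yet been measured. It differs from compound 3 in one place: ethoxy in place of methyl on an aromatic carbon, on an aromatic carbon of a six-membered aromatic ring of carbon only, para to a large group; cut one bond further out, 4-methylphenyl becomes 4-ethoxyphenyl. Going by the values given here, no measured step touches this change, and the one step that exists is unreadable, so there is nothing in the numbers to push the expectation up or down. The step of a 1.0-fold lower number from compound 3 to compound 4 (0.01 log units; within the scatter) is thus expected to fall within the usual scatter. Compound 4 is estimated to give 1200 nM, with a range from 400 nM to 3600 nM.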

Compound 4, half-maximal inhibitory concentration in the Chilo suppressalis assay: 646 nM
Estimate against measurement, compound 4: 1.9-fold (0.27 log units) above; the range from low to high includes it.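

In the Chilo suppressalis assay, where compound 3 gives 1230 nM and compound 4 gives 646 nM, the change from 4-methylphenyl to 4-ethoxyphenyl gives the only readable step among the compounds shown, a 1.9-fold lower number from compound 3 to compound 4 (0.28 log units; within the scatter), so ethoxy in place of methyl on this aromatic carbon, para to a large group, leaves the result within the scatter. In a physicochemical assay for lipophilicity, measured as octanol-water partition (a higher number here means a more lipophilic compound, a lower number a more polar compound), compound 3 gives 3.85 and compound 4 gives 3.75, and the same change reads a number 0.10 log units lower from compound 3 to compound 4 (within the scatter), which places compound 3 and compound 4 within the scatter of each other in both assays. The earlier compounds could show nothing of this kind, because the one step among them cannot be read, both of its ends being limits of the assay: the limit of > 5010 nM in the Chilo suppressalis assay, at which 2 of the 4 values shown sit.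

The compounds shown hold no amine, carboxylic acid or longer chain such as butoxy at this position, so how far the position accepts groups other than methyl and ethoxy stays open. Among the compounds shown here, they also leave open whether ethoxy in place of methyl would read the same with a different group on the amide side, such as the one in compound 1.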